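Shortening a Hydroxyalkyl Chain: Expected Clearance of Compound 3

The source may report more compounds than this note shows. Statements on the series, on what has been measured and on what is new or still open speak of the compounds shown alone.

Measured compounds:
compound 1 `CCCS(=O)(=O)Nc1ccc(F)c(-c2cc3cnc(NCC4CC4)nc3n(C)c2=O)c1F`: 17 mL/min/kg
compound 2 `CCCS(=O)(=O)Nc1ccc(F)c(-c2cc3cnc(NCCCO)nc3n(C)c2=O)c1F`: 46 mL/min/kg

Going by the values given here, in an in vitro ADME assay on cells (Hepatocyte, liver, Mus musculus) for pharmacokinetics (on this read-out lower numbers stand for slow clearance and higher numbers for fast clearance), compound 2 gives 46 mL/min/kg, the higher of the two numbers measured so far. Among the compounds with values here, its nearest neighbour is compound 1, which in this assay gives 17 mL/min/kg; the single step recorded, a 2.7-fold higher number from compound 1 to compound 2 (0.43 log units; beyond the scatter), lies beyond the scatter and replaces cyclopropyl with 2-hydroxyethyl on a saturated chain carbon bound to a nitrogen on an aromatic ring.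

Compound 3 `CCCS(=O)(=O)Nc1ccc(F)c(-c2cc3cnc(NCCO)nc3n(C)c2=O)c1F` differs from compound 2 by hydroxy in place of hydroxymethyl on a saturated chain carbon, two bonds along the chain from a nitrogen on an aromatic ring. Within the data shown here, no measured step bears directly on this change: the only step known, from compound 1 to compound 2, exchanges a ring for a hydroxyalkyl chain rather than removing one carbon from a chain that already carries a hydroxy group. With both neighbours bearing a terminal hydroxy group, the expectation is a step no larger than the usual scatter, a 1.2-fold lower number from compound 2 to compound 3 (0.08 log units; within the scatter), and no firm direction can be drawn.

On that basis compound 3 is estimated at 38 mL/min/kg in this assay, with a range from 19 mL/min/kg to 76 mL/min/kg.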

Compound 3, clearance: 75 mL/min/kg
For compound 3 the middle estimate is 2.0-fold (0.30 log units) below the measured one; the measured number falls inside the stated range.
By their numbers in this assay, from the lowest: compound 1; then compounds 2 and 3 (each within the scatter of the next).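

In this assay, cutting the chain from 3-hydroxypropyl to 2-hydroxyethyl gives a 1.6-fold higher number from compound 2 to compound 3 (0.21 log units; within the scatter) and so leaves no readable effect of chain length at this position, at least over this one carbon. Replacing the cyclopropyl of compound 1 with hydroxymethyl gives a 4.4-fold higher number from compound 1 to compound 3 (0.64 log units; beyond the scatter) and thus a step clear of the scatter, so each of the two hydroxy-ended chains shown stands apart from the cyclopropylmethyl compound, and none of the three compounds goes against this. No measurement at hand explains either step.

The compounds shown leave open whether this separation from compound 1 follows the terminal hydroxy group itself or the loss of the cyclopropyl ring, a question that a plain propyl chain or a methoxy-ended chain on the same nitrogen could address. They also leave open how a longer hydroxyalkyl chain, a terminal amine or a carboxylic acid in this place would read out in this assay on the shared core.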